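The source may report more compounds than this note shows. Statements on the series, on what has been measured and on what is new or still open speak of the compounds shown alone.

Values so far in an ADME assay on CEM-SS cells (Homo sapiens) for cytotoxicity, read by XTT assay, with a stated time of 6 days (a lower number here means that less compound is tolerated, a higher number that more compound is tolerated), all of them limits:
Compound 1 `CCCC(=O)OCSc1ccccc1C(=O)NCC(N)=O` gives > 100 uM as a limit
Compound 2 `CCCC(=O)OCSc1ccccc1C(=O)NCC(=O)NC` gives > 100 uM as a limit

Compound 2 stands only at the limit > 100 uM and offers no number to step from. Compound 3 `CCCC(=O)OCSc1ccccc1C(N)=O` differs from it by hydrogen in place of (methylcarbamoyl)methyl on an amide-type nitrogen. Within the data shown here, the one measured step is a step that the two limits leave unreadable from compound 1 to compound 2 and it is a different change, methyl in place of hydrogen, with no readable size. Among the measured compounds shown here, the only further guide is the limit of > 100 uM in this assay, at which 2 of the 2 values shown sit, for the series so far. In this assay no step beyond the scatter is therefore expected, and no direction can be given. The expected step is a number no higher from compound 2 to compound 3 (the limit leaves the size open) in this read-out. The estimated value for compound 3 is 100 uM with an expected range from 40 uM to 200 uM in this read-out.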

Compound 3, half-maximal toxic concentration: 12.4 uM
Compound 3: the middle estimate sits 8.1-fold (0.91 log units) above what was measured; measured number outside the range, below it.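

In this assay, the group on the amide-type nitrogen now has a readable effect: hydrogen in place of (methylcarbamoyl)methyl gives an at least 8.0-fold lower number from compound 2 to compound 3 (0.90 log units; beyond the scatter), and hydrogen in place of carbamoylmethyl gives an at least 8.0-fold lower number from compound 1 to compound 3 (0.90 log units; beyond the scatter). On these data alone, both steps lie beyond the scatter, but their full size stays open, as each starts from a limit and not from a number. The step between the two substituted compounds cannot be read, and the series otherwise sits at a ceiling: the limit of > 100 uM in this assay, at which 2 of the 3 values shown sit.

As far as these compounds go, it remains open whether any group on this nitrogen would keep the number at the limit, or whether the carbamoyl end is needed. A plain ethyl group, or a chain ending in a carboxylic acid or an amine, would separate these two readings.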